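The compounds below may be only part of what the source reports. "The series", "measured", "known", "first", "only" and "open" are said of these compounds alone.

Compound 1 `Nc1nc(NCc2cccs2)nc2sc(-c3ccco3)nc12` is one of two compounds tested in an assay on CHO cells for displacement of a labelled ligand from adenosine receptor A1 (Homo sapiens), read by scintillation counting, with a stated time of 90 min (on this read-out lower numbers stand for stronger inhibition and higher numbers for weaker inhibition), where compound 1 gives 12.5 nM, the lowest of the two numbers. The nearest measured compound, compound 2 `Nc1nc(NCc2ccccn2)nc2sc(-c3ccco3)nc12`, gives 28 nM in this assay. Among the compounds with values here, the single measured step, a 2.2-fold higher number from compound 1 to compound 2 (0.35 log units; beyond the scatter), exchanges one aromatic ring for another on a saturated chain carbon bound to a nitrogen on an aromatic ring. Compound 3 `Nc1nc(NCc2cnccn2)nc2sc(-c3ccco3)nc12` has not yet been measured; it differs from compound 1 by pyrazin-2-yl in place of thiophen-2-yl on a saturated chain carbon bound to a nitrogen on an aromatic ring. This change resembles the step from compound 1 to compound 2, since again a five-membered aromatic ring leaves and a six-membered aromatic ring enters at the same place, so a step of similar size and the same direction is expected, possibly a little larger. Compound 3 is therefore estimated at 35 nM, with a likely range from 15 nM to 85 nM. That corresponds to an expected step of a 2.8-fold higher number from compound 1 to compound 3 (0.45 log units; beyond the scatter).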

Compound 3, inhibition constant: 25 nM
Compound 3: the middle estimate sits 1.4-fold (0.15 log units) above what was measured; measured number inside the range.
By their numbers in this assay, from the lowest: compounds 1, 3 and 2 (each within the scatter of the next, the first and the last beyond it).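

In this assay, replacing thiophen-2-yl with pyrazin-2-yl on a saturated chain carbon bound to a nitrogen on an aromatic ring gives a result that cannot be separated from the usual scatter (a 2.0-fold higher number from compound 1 to compound 3 (0.30 log units; within the scatter)). Replacing pyridin-2-yl with pyrazin-2-yl likewise gives no readable difference (a 1.1-fold lower number from compound 2 to compound 3 (0.05 log units; within the scatter)), so the second ring nitrogen of pyrazin-2-yl is tolerated here, even though compound 1 and compound 2 do differ beyond the scatter. No measurement shown explains why these rings give such close numbers.

On these data alone, it remains open whether this place needs an aromatic ring at all, which a cyclohexyl ring or a simple ethyl chain could test. Also open, as far as these compounds go, is how a methoxy group, a chlorine atom or a carboxylic acid on the ring would read.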